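A few compounds are considered here, and "the series" means these few. Any claim that something is new, unique, unknown or untested is made for them only; others in the source may bear on it.

Compound 1 `Cc1nc(Nc2cccc(Cl)c2)sc1C(=O)/C=C/c1ccc(Cl)cc1` is the reference point of this pair. In a functional assay on PC-3 cells (Homo sapiens) for cytotoxicity, read by MTT assay (a higher number here means a weaker inhibitor, a lower number a stronger inhibitor), compound 1 gives only a limit, > 25000 nM, not a number. Within the data shown here, its one measured neighbour that differs in a single place is compound 2 `COc1cccc(/C=C/C(=O)c2sc(Nc3cccc(Cl)c3)nc2C)c1`. In this assay compound 2 also gives only a limit, > 25000 nM. Among the measured compounds shown here, the single measured step, a step that the two limits leave unreadable from compound 1 to compound 2, cannot be sized because of the limit of > 25000 nM in this assay, at which 2 of the 2 values shown sit. Compound 3 `Cc1nc(Nc2ccc(Cl)c(Cl)c2)sc1C(=O)/C=C/c1ccc(Cl)cc1` is not yet measured in this assay. It differs from compound 1 by chloro in place of hydrogen on an aromatic carbon. For the measured compounds named here, no measured step touches the 3-chlorophenyl, so the known data give no size and no direction for a chloro entering there; the step from compound 1 to compound 2 is itself unreadable. With both known values at the limit, the expected outcome is a value at or near the same limit. The step is expected to be a number no higher from compound 1 to compound 3 (the limit leaves the size open). Compound 3 is estimated at 25000 nM, within 8000 nM to 100000 nM.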

Compound 3, half-maximal inhibitory concentration: > 25000 nM
Compound 3: a limit, no number; the forecaster's own chance of this, stated with the estimate: 75%; the middle value sits exactly at the limit.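

Among these compounds, compound 3, like compound 1, gives only a limit in this assay, so no step between them can be read: the limit of > 25000 nM in this assay, at which 3 of the 3 values shown sit. The compounds shown leave open the size and direction of the change from 3-chlorophenyl to 3,4-dichlorophenyl, and which change would give a readable number.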